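Bromo in Place of Methyl: From Compound 1 to Compound 4

This account rests on a few compounds, and the source may have more. Where it says the series, first, only, none or still open, it means among the compounds named here.

Measured in a functional assay on C6 cells (Rattus norvegicus) for cytotoxicity, read by MTT assay, with a stated time of 24 h, tested at 25 ug/mL; on this read-out lower numbers stand for a stronger effect and higher numbers for a weaker effect at the one concentration tested:
Compound 1 `Cc1ccc(-c2cs/c(=N/NC(=O)CSc3nnnn3-c3ccccc3)n2-c2ccccc2)cc1` gives 38.8%
Compound 2 `Cn1cnnc1SCC(=O)N/N=c1/scc(-c2ccc(C#N)cc2)n1-c1ccccc1` gives 58.8%
Compound 3 `Cn1nnnc1SCC(=O)N/N=c1/scc(-c2ccc([N+](=O)[O-])cc2)n1-c1ccccc1` gives 69.3%

Among these three numbers compound 1 stands lowest in this assay, which on this read-out means the strongest effect: compound 2 lies beyond the usual scatter above it, and compound 3 lies further still. Compound 4 `O=C(CSc1nnnn1-c1ccccc1)N/N=c1/scc(-c2ccc(Br)cc2)n1-c1ccccc1` has not yet been measured. It differs from compound 1 in one place: bromo in place of methyl on an aromatic carbon. Going by the values given here, no pair of measured compounds shows this same change, so its effect in this assay is unknown from the data at hand. Since compound 1 shows 38.8%, the expected step is a number 3.2 percentage points higher from compound 1 to compound 4 (within the scatter), small and within or close to the scatter. Compound 4 is therefore expected to give 42%, within 25% to 62%.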

Compound 4, a percentage reported as activity, at one concentration (the size of the read-out at that concentration, not a potency): 47.9%
Beside the measured number, compound 4's estimate is 5.9 percentage points below it; the measured number falls inside the stated range.
By their numbers in this assay, from the lowest: compounds 1 and 4 (each within the scatter of the next); then compound 2; then compound 3.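

In this assay, going by these compounds alone, bromo in place of methyl on the aromatic carbon gives a number 9.1 percentage points higher from compound 1 to compound 4 (within the scatter), the first direct reading of this change. At this position, therefore, the 4-methylphenyl and 4-bromophenyl groups cannot be told apart in this test. Nothing measured here offers an explanation for this result.

As far as these compounds go, it remains open whether an amine or a carboxylic acid at the same position would also stay within the scatter of compound 1. The compounds shown also leave open whether this same change would read alike on another core.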